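Swapping chloro for hydroxy on a second core

The source may report more compounds than this note shows. Statements on the series, on what has been measured and on what is new or still open speak of the compounds shown alone.

Compound 1 `N#Cc1c(-c2ccc(Cl)cc2)nc(SCC(=O)Nn2c(COc3ccc(Cl)cc3Cl)nc3ccccc3c2=O)n(Cc2ccccc2)c1=O` gives 77.2% in a functional assay on the whole organism (strain albino) for inhibition, with Rattus norvegicus as the target, read by paw edema, with stated times of 1 h and 2 h, at a dose of 100 mg/kg by the oral route; a lower number here means less inhibition, a higher number more inhibition at the dose given (going by the name of the read-out). Compound 2 `N#Cc1c(-c2ccc(O)cc2)nc(SCC(=O)Nn2c(COc3ccc(Cl)cc3Cl)nc3ccccc3c2=O)n(Cc2ccccc2)c1=O` gives 56.1%, so the step of a number 21.1 percentage points lower from compound 1 to compound 2 (beyond the scatter) follows from the change (hydroxy in place of chloro on an aromatic carbon). Compound 3 `N#Cc1c(Nc2ccc(Cl)cc2)nc(SCC(=O)Nn2c(COc3ccc(Cl)cc3Cl)nc3ccccc3c2=O)nc1-c1ccccc1` is built on a different core; the difference between the two cores is not broken down here. In this assay compound 3 gives 57.9%. Compound 4 `N#Cc1c(Nc2ccc(O)cc2)nc(SCC(=O)Nn2c(COc3ccc(Cl)cc3Cl)nc3ccccc3c2=O)nc1-c1ccccc1` carries the same change, (hydroxy in place of chloro on an aromatic carbon), at the same kind of place, now within a (4-chlorophenyl)amino group rather than a 4-chlorophenyl group. Going by the values given here, a similar step is expected from compound 3 to compound 4, a number 15.9 percentage points lower from compound 3 to compound 4 (beyond the scatter), because the only measured example of this change gave a number 21.1 percentage points lower from compound 1 to compound 2 (beyond the scatter). Compound 4 is therefore estimated at 42%, with a range from 28% to 58%.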

Compound 4, a percentage reported as inhibition, in the whole organism at one dose (the size of the read-out at that dose, not a potency): 59.7%
Compound 4: the middle estimate sits 17.7 percentage points below what was measured; measured number above the stated range.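

In this assay, hydroxy in place of chloro within the (4-chlorophenyl)amino group gives a number 1.8 percentage points higher from compound 3 to compound 4 (within the scatter), so on this core the swap leaves no readable difference. Set beside the earlier step, the same change does not carry over from one core to the other in this series: the same change on two cores in this assay, a number 21.1 percentage points lower (beyond the scatter) from compound 1 to compound 2 and a number 1.8 percentage points higher (within the scatter) from compound 3 to compound 4, 22.9 percentage points apart, beyond the scatter of two such steps. Going by these compounds alone, with only two such pairs, this does not show which difference between the cores matters, or which of the two steps is the more typical.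

The compounds shown leave open how a methoxy group or a carboxylic acid in the same place would behave on either core. They also leave open which of the two steps a third core would resemble.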